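A few compounds are considered here, and "the series" means these few. Any claim that something is new, unique, unknown or untested is made for them only; others in the source may bear on it.

Working notes on the series. In an ADME assay on L1210/0 cells (Mus musculus) for cytotoxicity, with a stated time of 48 h (a lower number here means a stronger inhibitor, a higher number a weaker inhibitor), compound 3 `COCC#Cc1cn([C@H]2C[C@H](O)[C@@H](CO)O2)c(=O)[nH]c1=O` gives only a limit, > 200000 nM, and not a number. Compound 2 `Nc1ncnc2c1ncn2CC1CCC(CO)C1` likewise returns only a limit in this assay, > 200000 nM. For the measured compounds named here, compound 1 `[N-]=[N+]=NCc1cn([C@H]2C[C@H](O)[C@@H](CO)O2)c(=O)[nH]c1=O` gives 124000 nM in this assay, the one value in the set that is a number. Compound 3 therefore stands at the limit of > 200000 nM in this assay, at which 2 of the 3 values shown sit, with nothing to separate it from compound 2 and only a floor separating it from compound 1.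

Going by the values given here, the single measured step that bears on the present change is an at least 1.6-fold higher number from compound 1 to compound 3 (0.20 log units; that floor lies within the scatter), a change on an aromatic carbon of the shared core; it is a floor rather than a size, and that floor lies within the scatter. Compound 4 `O=c1[nH]c(=O)n([C@H]2C[C@H](O)[C@@H](CO)O2)cc1/C=C/Cl` differs from compound 3 as follows: 2-chloroethenyl in place of 3-methoxyprop-1-yn-1-yl on an aromatic carbon.

Among the compounds with values here, with two of three values at the limit and the only step on that carbon within the scatter, no step beyond the scatter is expected in this assay, and a further limit is a real possibility. The expected step is an at least 1.6-fold lower number from compound 3 to compound 4 (0.22 log units; that floor lies within the scatter). Compound 4 is estimated at 120000 nM, between 30000 nM and 250000 nM.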

Compound 4, half-maximal inhibitory concentration: > 200000 nM
Compound 4 ended at the assay's limit; the forecaster's own chance of this, stated with the estimate: 45%; middle value at least 1.6-fold (0.22 log units) from the limit.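

Compound 4 gives only a limit and not a number in this assay, so a second group on this aromatic carbon, 2-chloroethenyl, ends where 3-methoxyprop-1-yn-1-yl ended: the limit of > 200000 nM in this assay, at which 3 of the 4 values shown sit.

Against azidomethyl the change gives an at least 1.6-fold higher number from compound 1 to compound 4 (0.20 log units; that floor lies within the scatter), a floor of the same kind as an at least 1.6-fold higher number from compound 1 to compound 3 (0.20 log units; that floor lies within the scatter), so azidomethyl remains the only group on this carbon with a number, and neither floor separates it from the others beyond the scatter. The step between the two limits cannot be read, so exchanging the triple bond of one chain for the double bond of the other has no size here.

As far as these compounds go, whether compound 3 and compound 4 differ at all in this assay stays open. From the compounds shown here alone, what an amine or a carboxylic acid on this aromatic carbon would give also stays open, as does whether any group here departs from compound 1 beyond the scatter.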